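This account rests on a few compounds, and the source may have more. Where it says the series, first, only, none or still open, it means among the compounds named here.

In a functional assay on HCT-15 cells (Homo sapiens) for cytotoxicity, read by CCK-8 assay and cell counting, with a stated time of 2 days (on this read-out lower numbers stand for stronger inhibition and higher numbers for weaker inhibition), compound 1 `Oc1cccc(-c2cc(-c3ccc(Cl)cc3)nc(-c3cccs3)c2)c1` gives 9280 nM, compound 2 `Oc1cccc(-c2cc(-c3ccc(Cl)cc3)nc(-c3ccccn3)c2)c1` gives 13500 nM, and compound 3 `Oc1cccc(-c2cc(-c3cccc(Cl)c3)nc(-c3cccs3)c2)c1` gives 2610 nM, the lowest of the three numbers. The nearest measured number is reached by a 3.6-fold lower number from compound 1 to compound 3 (0.55 log units; beyond the scatter), while compound 2 lies further off. Compound 4 `Oc1cccc(-c2cc(-c3ccccc3)nc(-c3cccc(Cl)c3)c2)c1` differs from compound 3 in one place: phenyl in place of thiophen-2-yl on an aromatic carbon. Among the compounds with values here, the only measured step that touches the same position is a 1.5-fold higher number from compound 1 to compound 2 (0.16 log units; within the scatter), where the thiophen-2-yl was likewise exchanged for a six-membered aromatic ring without a change beyond the scatter. On that basis no step beyond the scatter is expected in this assay. For compound 4 the estimate is 3000 nM, with a range from 1200 nM to 8000 nM, which amounts to an expected 1.1-fold higher number from compound 3 to compound 4 (0.06 log units; within the scatter).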

Compound 4, half-maximal inhibitory concentration: 2550 nM
Compound 4: the middle estimate sits 1.2-fold (0.07 log units) above what was measured; low and high end bracket the measured number.
By their numbers in this assay, from the lowest: compounds 4 and 3 (each within the scatter of the next); then compounds 1 and 2 (each within the scatter of the next).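

In this assay, replacing thiophen-2-yl with phenyl next to the ring nitrogen gives a 1.0-fold lower number from compound 3 to compound 4 (0.01 log units; within the scatter), although a five-membered ring containing sulfur gives way to a six-membered ring of carbon only. The earlier exchange introduced pyridin-2-yl, which still carries a ring nitrogen, whereas this result shows that an all-carbon ring also stays within the scatter, here with a 3-chlorophenyl group on the core. Nothing available explains this lack of change.

On these data alone, whether this position accepts a non-aromatic group, such as an amine or a short alkyl chain, remains open.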